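A few compounds are considered here, and "the series" means these few. Any claim that something is new, unique, unknown or untested is made for them only; others in the source may bear on it.

Among the measured compounds shown here, compound 2 `CC(C)(C)c1ccc(C(=O)N2CCC3(CC2)C(=O)N(CC(=O)NCCO)CN3c2ccccc2)cc1` holds the lowest of the two numbers so far: in an assay on HEK293 cells for displacement of a labelled ligand from NPC1-like intracellular cholesterol transporter 1 (Homo sapiens) (on this read-out lower numbers stand for stronger inhibition and higher numbers for weaker inhibition), compound 2 gives 1000 nM, while its nearest neighbour, compound 1 `CC(C)(C)OC(=O)NCCCNC(=O)CN1CN(c2ccccc2)C2(CCN(C(=O)c3ccc(C(C)(C)C)cc3)CC2)C1=O`, in this assay gives 4500 nM. Compound 3 `CC(C)(C)c1ccc(C(=O)N2CCC3(CC2)C(=O)N(CC(=O)N2CCN(S(C)(=O)=O)CC2)CN3c2ccccc2)cc1` differs from compound 2 by 4-(methylsulfonyl)piperazin-1-yl in place of (2-hydroxyethyl)amino on a carbonyl carbon. For the measured compounds named here, the only measured step, a 4.5-fold lower number from compound 1 to compound 2 (0.65 log units; beyond the scatter), changed the chain beyond the amide-type nitrogen rather than the carbonyl carbon, so it bears on this change only loosely. The expected step of a 1.5-fold higher number from compound 2 to compound 3 (0.18 log units; within the scatter) is therefore modest and uncertain in direction. Compound 3 is estimated at 1500 nM, between 400 nM and 6000 nM.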

Compound 3, half-maximal inhibitory concentration: 19000 nM
The estimate for compound 3 lay 13-fold (1.10 log units) below the measured number; the whole stated range lies below it.
By their numbers in this assay, from the lowest: compound 2; then compound 1; then compound 3.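

At the carbonyl carbon whose other neighbour is a saturated chain carbon, the group matters strongly in this assay: 4-(methylsulfonyl)piperazin-1-yl in place of (2-hydroxyethyl)amino raises the number sharply (a 19-fold higher number from compound 2 to compound 3 (1.28 log units; beyond the scatter)). The same group also compares unfavourably with (3-((tert-butoxycarbonyl)amino)propyl)amino (a 4.2-fold higher number from compound 1 to compound 3 (0.63 log units; beyond the scatter)), so both chain amides shown hold lower numbers than this ring-bearing amide. Nothing measured here gives a reason for these steps. On these data alone, whether the loss follows the ring or its methylsulfonyl group stays open; a piperazine without methylsulfonyl, or a morpholine, on this carbonyl carbon would bear on that.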